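From 2-Ethylphenyl to 4-Methoxy-2-methylphenyl

The source may report more compounds than this note shows. Statements on the series, on what has been measured and on what is new or still open speak of the compounds shown alone.

In an ADME assay (liver) for metabolic stability, with Liver microsome (Canis lupus familiaris) as the target, read by LC-MS, using microsomes, with a stated time of 30 min, tested at 4 uM (a higher number here means that more of the compound is left, a lower number that less of the compound is left), compound 3 `CCc1ccccc1-c1nc2c(N3CCN(C)CC3)nc(C)nc2n1C1CCOCC1` gives 74%, the highest of three numbers. Compound 1 `Cc1nc(N2CCN(C)CC2)c2nc(-c3cccc(C(F)(F)F)c3)n(C3CCOCC3)c2n1` gives 44%, and compound 2 `Cc1nc(N2CCN(C)CC2)c2nc(-c3ccccc3C)n(C3CCOCC3)c2n1` gives 39%. Compound 4 `COc1ccc(-c2nc3c(N4CCN(C)CC4)nc(C)nc3n2C2CCOCC2)c(C)c1` has 4-methoxy-2-methylphenyl in place of 2-ethylphenyl on an aromatic carbon. The closest guide is the change from 2-methylphenyl to 2-ethylphenyl, which gave a number 35 percentage points higher from compound 2 to compound 3 (beyond the scatter). Swapping 3-(trifluoromethyl)phenyl for 2-ethylphenyl gave a number 30 percentage points higher from compound 1 to compound 3 (beyond the scatter), while swapping it for 2-methylphenyl gave a number 5 percentage points lower from compound 1 to compound 2 (within the scatter). Among the compounds with values here, only compound 3 carries 2-ethylphenyl, and no measured compound shows what the added methoxy does, so a clear fall is expected, of uncertain size. The expected change is a number 32 percentage points lower from compound 3 to compound 4 (beyond the scatter). For compound 4, the estimate is 42%, within a range of 22% to 62%.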

Compound 4, percent of the compound remaining: 41%
For compound 4 the middle estimate is 1 percentage points above the measured one, within the range that was stated.
By their numbers in this assay, from the lowest: compounds 2, 4 and 1 (each within the scatter of the next); then compound 3.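

In this assay, the high number of compound 3 does not carry over to 4-methoxy-2-methylphenyl (a number 33 percentage points lower from compound 3 to compound 4 (beyond the scatter)). Methoxy in place of hydrogen on 2-methylphenyl makes no real difference (a number 2 percentage points higher from compound 2 to compound 4 (within the scatter)), and the same holds for the swap from 3-(trifluoromethyl)phenyl (a number 3 percentage points lower from compound 1 to compound 4 (within the scatter)), so among these four compounds only 2-ethylphenyl stands apart at this position. Nothing available explains why.

Open, as far as these compounds go, is whether a longer chain such as propyl in place of the ethyl group would keep the number of compound 3, and whether methoxy added to 2-ethylphenyl would lower it.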